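Swapping an Aromatic Ring for a Saturated One

The compounds below may be only part of what the source reports. "The series", "measured", "known", "first", "only" and "open" are said of these compounds alone.

Of the compounds shown here, three sharing one core have been measured in an ADME assay for permeability, using PAMPA, with a stated time of 30 min, at pH 7.4; a lower number here means that the compound crosses the layer more slowly, a higher number that the compound crosses the layer faster. Compound 1 `CC(C)Cc1ccc2c(NCCCNCc3ccco3)ccnc2c1` gives 23 10^-6 cm/s, compound 2 `COc1ccc(Oc2ccc3c(NCCCNCc4ccco4)ccnc3c2)cc1` gives 317 10^-6 cm/s, and compound 3 `CC(C)(C)c1ccc(-c2ccc3c(NCCCNCc4ccco4)ccnc3c2)cc1` gives 237 10^-6 cm/s. Compound 3 therefore stands second highest of the three, close to compound 2 and far from compound 1. The recorded steps are a 14-fold higher number from compound 1 to compound 2 (1.14 log units; beyond the scatter) and a 10-fold higher number from compound 1 to compound 3 (1.01 log units; beyond the scatter), while a 1.3-fold lower number from compound 2 to compound 3 (0.13 log units; within the scatter).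

Compound 4 `c1coc(CNCCCNc2ccnc3cc(C4CCCCC4)ccc23)c1` is the next to be measured in this assay. Its change from compound 3 is cyclohexyl in place of 4-(tert-butyl)phenyl on an aromatic carbon The relevant comparison is the step from compound 1 to compound 3, where isobutyl gave way to 4-(tert-butyl)phenyl and the number rose strongly because a 10-fold higher number from compound 1 to compound 3 (1.01 log units; beyond the scatter). Cyclohexyl, at 6 heavy atoms, falls between isobutyl and 4-(tert-butyl)phenyl in heavy-atom count, so a number between those of compound 1 and compound 3 is expected, with the step likely beyond the scatter. The expected step is a 3.0-fold lower number from compound 3 to compound 4 (0.47 log units; beyond the scatter). Compound 4 is estimated to give 80 10^-6 cm/s in this assay, within a range from 25 10^-6 cm/s to 250 10^-6 cm/s.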

Compound 4, apparent permeability: 23 10^-6 cm/s
The estimate for compound 4 lay 3.5-fold (0.54 log units) above the measured number, outside the stated range (below it).
By their numbers in this assay, from the lowest: compounds 1 and 4 (each within the scatter of the next); then compounds 3 and 2 (each within the scatter of the next).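

In this assay, a six-membered ring at this position does not by itself keep the number high. Cyclohexyl, a non-aromatic ring, shows no change at the digits printed from compound 1 to compound 4 (within the scatter), so it cannot be told apart from the open-chain isobutyl group. Both groups that carry an aromatic ring stand well clear of it, with a 10-fold lower number from compound 3 to compound 4 (1.01 log units; beyond the scatter) and a 14-fold lower number from compound 2 to compound 4 (1.14 log units; beyond the scatter), so among these four compounds the two high numbers go with an aromatic ring in the group and the two low numbers with its absence.

The swap from compound 3 to compound 4 removes the aromatic ring and the tert-butyl group together, so a plain phenyl or a 4-(tert-butyl)cyclohexyl group at this place would be needed to show which of the two the large step follows. No measurement at hand explains why the number falls so far.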